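Swapping a Methyl for a Carboxy on the Ring

The source may report more compounds than this note shows. Statements on the series, on what has been measured and on what is new or still open speak of the compounds shown alone.

Compound 1 `Cc1ccccc1CCCCCCC(=O)N1CCCC1`, compound 2 `Cc1cccc(CCCCCCC(=O)N2CCCC2)c1` and compound 3 `O=C(CCCCCCc1ccc(O)cc1)N1CCCC1` share one core and differ only in the small group carried by the six-membered aromatic ring of carbon only. In an assay on HEK293 cells for inhibition of N-acylethanolamine-hydrolyzing acid amidase (Rattus norvegicus), read by LC-MS, with a stated time of 30 min (a lower number here means a stronger inhibitor, a higher number a weaker inhibitor), compound 1 gives 68400 nM, compound 2 gives 8300 nM, and compound 3 gives 5600 nM. Among these three numbers compound 2 stands second highest. Its nearest neighbour is compound 3, at a gap that lies within the usual scatter of repeated measurements, so the two cannot be told apart on these data. Compound 1 stands furthest off, at a gap well beyond the scatter.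

Compound 4 `O=C(O)c1cccc(CCCCCCC(=O)N2CCCC2)c1` has not yet been measured. It differs from compound 2 by carboxy in place of methyl on an aromatic carbon. Among the compounds with values here, no pair of measured compounds shows this exchange, so its effect cannot be read off directly; the three measured compounds show only that changing the ring substituent can move the result anywhere from within the scatter to far beyond it. In this assay the expected step is a 1.8-fold higher number from compound 2 to compound 4 (0.26 log units; within the scatter), a modest shift toward a weaker inhibitor, though a result within the scatter would not surprise. Compound 4 is therefore estimated at 15000 nM, within a range from 4000 nM to 60000 nM.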

Compound 4, half-maximal inhibitory concentration: > 100000 nM
Compound 4 gave a limit, no number; the forecaster's own chance of this, stated with the estimate: 15%; middle value at least 6.6-fold (0.82 log units) from the limit.
By their numbers in this assay, from the lowest: compounds 3 and 2 (each within the scatter of the next); then compound 1. At a limit, above all of these: compound 4.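

Carboxy in place of methyl on an aromatic carbon, meta to a large group, is the first exchange in this series that can be read directly, and in this assay it gives an at least 12-fold higher number from compound 2 to compound 4 (1.08 log units; beyond the scatter). Compound 4 stands as a limit of the assay and not as a number: the limit of > 100000 nM in this assay, at which 1 of the 4 values shown sits. Within the data shown here, the earlier compounds showed only that results differ among compounds with different ring groups, whereas this single exchange ties a large move toward a weaker inhibitor to one specific swap at this position, where the entering carboxy brings one hydrogen-bond donor and one hydrogen-bond acceptor and the leaving methyl brings neither.

One pair cannot show which part of the carboxy goes with this move, whether its two oxygen atoms, its hydrogen-bond donor or the group as a whole. A methyl ester or a primary amide at the same place would separate these parts, and an amine or a hydroxymethyl there would show whether other groups with a hydrogen-bond donor follow the same course.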